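Aromatic fluoro substitution in the shared core series

This account rests on a few compounds, and the source may have more. Where it says the series, first, only, none or still open, it means among the compounds named here.

Measured so far in a functional assay on HEK293 cells with Glucose-dependent insulinotropic receptor (Homo sapiens) as the target, read by cAMP accumulation, with a stated time of 60 min; on this read-out lower numbers stand for smaller maximal responses and higher numbers for larger maximal responses:
compound 1, `CCCc1cnc(N2CCC(C3Cc4cc(C5=CCN(S(=O)(=O)CCC)CC5)ccc4O3)CC2)nc1`, gives 107%;
compound 2, `CCCc1cnc(N2CCC(C3Cc4c(ccc(C5=CCN(S(=O)(=O)CCC)CC5)c4F)O3)CC2)nc1`, gives 123%;
compound 3, `CCCc1cnc(N2CCC(C3Cc4cc(C5=CCN(S(=O)(=O)CCCO)CC5)cc(F)c4O3)CC2)nc1`, gives 92%.

In this assay the step of a number 16 percentage points higher from compound 1 to compound 2 (beyond the scatter) comes with the change (fluoro in place of hydrogen on an aromatic carbon). Compound 3 is the lowest of the three; the difference between its core and the core of compound 1 is not broken down here. Compound 4, `CCCc1cnc(N2CCC(C3Cc4c(F)c(C5=CCN(S(=O)(=O)CCCO)CC5)cc(F)c4O3)CC2)nc1`, carries the change (fluoro in place of hydrogen on an aromatic carbon). This is the same kind of change as from compound 1 to compound 2, but the place differs: here the entering fluoro is also para to a fluoro group. Because a number 16 percentage points higher from compound 1 to compound 2 (beyond the scatter) was a modest rise, a step of similar size, a number 14 percentage points higher from compound 3 to compound 4 (beyond the scatter), is expected here. Compound 4 is therefore estimated at 106%, with a likely range from 90% to 122% in this assay.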

Compound 4, largest response reached (Emax), in percent of the reference or control that the assay uses: 86%
Compound 4: middle estimate off by 20 percentage points, on the high side; the whole stated range lies above it.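

In this assay, fluoro in place of hydrogen on an aromatic carbon gives a number 6 percentage points lower from compound 3 to compound 4 (within the scatter), so the modest rise seen with this change on the core of compound 1 does not carry over to this pair. The two steps do not agree across the two cores: the same change on two cores in this assay, a number 16 percentage points higher (beyond the scatter) from compound 1 to compound 2 and a number 6 percentage points lower (within the scatter) from compound 3 to compound 4, 22 percentage points apart, beyond the scatter of two such steps

Among the compounds shown here, with only one pair per core, this shows that the step cannot be assumed to transfer, but not which structural difference between the pairs goes with the gap. The entering fluoro sits at a different place, and compound 4 also carries a second fluoro and a chain ending in hydroxyl.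

Going by these compounds, it remains open whether chloro or methoxy at the same aromatic carbon would follow either step. On these data alone, it also remains open whether a plain propyl chain on the core of compound 3 would restore the rise.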